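This account rests on a few compounds, and the source may have more. Where it says the series, first, only, none or still open, it means among the compounds named here.

Compound 1 `O=Cc1c(Nc2ccccc2)oc2ccccc2c1=O` is the parent of this short series. In a functional assay on PC-3 cells (Homo sapiens) for cytotoxicity, read by MTT assay, with a stated time of 48 h (on this read-out lower numbers stand for higher toxicity in this test and higher numbers for lower toxicity in this test), compound 1 gives 8200 nM, which is the higher of the two numbers in hand. Among the measured compounds shown here, its only measured neighbour is compound 2 `O=Cc1c(Nc2ccccc2)oc2cc(Cl)ccc2c1=O`, where a 3.3-fold lower number from compound 1 to compound 2 (0.52 log units; beyond the scatter), and in this assay compound 2 gives 2500 nM.

Compound 3 `CN(c1ccccc1)c1oc2ccccc2c(=O)c1C=O` is not yet measured. Relative to compound 1 the change is methyl in place of hydrogen on a nitrogen on an aromatic ring. For the measured compounds named here, no measured step touches this nitrogen: the one step in hand, from compound 1 to compound 2, concerns a chloro on an aromatic carbon of the shared core and says nothing about substitution of the amine hydrogen. Going by the values given here, with no comparable precedent, the expectation for compound 3 in this assay is a number close to that of compound 1, a step of a 1.2-fold higher number from compound 1 to compound 3 (0.09 log units; within the scatter) and not clearly beyond the scatter. The estimate for compound 3 is therefore 10000 nM, with a range from 3000 nM to 30000 nM.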

Compound 3, concentration lethal to 50% of the cells: 500 nM
Compound 3: the middle estimate sits 20-fold (1.30 log units) above what was measured; the measured number lies below the stated range.
By their numbers in this assay, from the lowest: compound 3; then compound 2; then compound 1.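

Methyl in place of hydrogen on a nitrogen on an aromatic ring gives a 16-fold lower number from compound 1 to compound 3 (1.21 log units; beyond the scatter) in this assay and so marks this nitrogen as a sensitive point in the series. The step is large, while the chloro change on the shared core gave the modest 3.3-fold lower number from compound 1 to compound 2 (0.52 log units; beyond the scatter) and left this nitrogen untouched. No supporting data bear on why the methyl step is this large.

From the compounds shown here alone, it remains open whether the lower number is particular to methyl or extends to a longer chain such as ethyl or to an acetyl group on the same nitrogen. Going by these compounds, it also remains open whether the methyl and chloro changes add up in a single compound carrying both on the shared core.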